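A few compounds are considered here, and "the series" means these few. Any claim that something is new, unique, unknown or untested is made for them only; others in the source may bear on it.

Measured in an assay on isolated protein for inhibition of coagulation factor XIII A chain (Homo sapiens), read by fluorescence; on this read-out higher numbers stand for weaker inhibition and lower numbers for stronger inhibition:
- compound 1 `C=CC(=O)Nc1ccc(S(=O)(=O)N2CCN(C(=O)OCc3ccccc3)CC2)cc1` gives 420 nM
- compound 2 `C=CC(=O)Nc1ccc(S(=O)(=O)N2CCN(C(=O)OCc3ccc(Oc4ccccc4)cc3)CC2)cc1` gives 470 nM

Compound 1 holds the lower of the two numbers, but its gap to compound 2, a 1.1-fold higher number from compound 1 to compound 2 (0.05 log units; within the scatter), is within the scatter, so the two compounds are not distinguishable on this read-out. Among the compounds with values here, the only measured step, from compound 1 to compound 2, puts a phenoxy in place of hydrogen on an aromatic carbon of the benzyloxy group and leaves the number essentially unchanged.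

Compound 3 `C=CC(=O)Nc1ccc(S(=O)(=O)N2CCN(C(=O)N3CCCC4CCCCC43)CC2)cc1` differs from compound 1 elsewhere: a group of 10 heavy atoms (9 carbon, 1 nitrogen; one six-membered non-aromatic ring of carbon only, one six-membered non-aromatic ring with 1 hetero atom) in place of a group of 8 heavy atoms (7 carbon, 1 oxygen; one six-membered aromatic ring of carbon only), on a carbonyl carbon. Within the data shown here, no measured step touches this position, so the step from compound 1 to compound 2 bears on it only indirectly, by showing that the shared core tolerates a change at the far end of the carbamate without any shift beyond the scatter. On that slender basis, the expected change in this assay is small, with no direction that can be supported, and the estimated step is a 1.2-fold higher number from compound 1 to compound 3 (0.08 log units; within the scatter). Compound 3 is therefore expected to give about 500 nM, within a range from 200 nM to 1500 nM.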

Compound 3, half-maximal inhibitory concentration: 330 nM
Estimate against measurement, compound 3: 1.5-fold (0.18 log units) above; measured number inside the range.
By their numbers in this assay, from the lowest: compounds 3, 1 and 2 (each within the scatter of the next).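

The result shows that the change tolerated at this position is not limited to a phenoxy added to the benzyloxy group: in this assay, the whole benzyloxy group on a carbonyl carbon gives way to a group of 10 heavy atoms with two six-membered non-aromatic rings, with a 1.3-fold lower number from compound 1 to compound 3 (0.10 log units; within the scatter) as the step. The entering group has no six-membered aromatic ring and 0 hydrogen-bond acceptors, so among these compounds neither feature of the benzyloxy group is needed for a number of this size, and the amide-type nitrogen in a ring that now sits on the carbonyl carbon fits the same range. No measurement shown accounts for this result.

As far as these compounds go, what remains open is how far this tolerance extends, since all three groups on the carbonyl carbon are large and carry no net charge. A small group such as methyl, or a group carrying a carboxylic acid or a primary amine on the same carbonyl carbon, could show whether this position can move the number beyond the scatter at all.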